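The compounds below may be only part of what the source reports. "The series", "measured", "known", "first", "only" and "open" are said of these compounds alone.

Compound 1, `COc1ccc(CNc2nc([SeH])nc3ccccc23)cc1`, gives in a functional assay on CCRF-CEM cells (Homo sapiens) for cytotoxicity, read by MTT assay, with a stated time of 72 h (a higher number here means that more compound is tolerated, a lower number that less compound is tolerated), the value > 100000 nM, which is a limit of the assay rather than a number.
Compound 2, `C[Se]c1nc(N)c2ccccc2n1`, gives in this assay the value > 100000 nM, again a limit rather than a number.
Compound 3, `COc1ccc(CNc2nc(SC)nc3ncccc23)cc1`, gives in this assay the value > 100000 nM, also a limit rather than a number.

Compound 1 therefore stands at the top of what the measurement can report: the limit of > 100000 nM in this assay, at which 3 of the 3 values shown sit. For the measured compounds named here, none of the three measured compounds shows a countable loss of cells within the tested range, so no step between measured compounds can be drawn, and nothing in these data separates one compound from another.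

The next compound, compound 4, `COc1ccc(CNc2nc(SC)nc3ccccc23)cc1`, differs from compound 1 in one place: a group of 2 heavy atoms (1 carbon, 1 sulfur; no ring) in place of one selenium atom, on an aromatic carbon. Compound 3 already carries the same methylsulfanyl group on a closely related core, and its reading is a limit as well. With every measured value sitting at the limit, the step from compound 1 to compound 4 is expected to be none beyond the scatter, that is a number no higher from compound 1 to compound 4 (the limit leaves the size open) in this assay. Compound 4 is accordingly estimated at 100000 nM, with a range from 50000 nM to 300000 nM, and the measurement is expected most likely to return only a limit again.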

Compound 4, concentration lethal to 50% of the cells: > 100000 nM
Compound 4 ended at the assay's limit; the forecaster's own chance of this, stated with the estimate: 85%; the middle value lies on the limit itself.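

No step can be read between compound 1 and compound 4, because each reading is a limit and not a number: the limit of > 100000 nM in this assay, at which 4 of the 4 values shown sit. The compounds shown leave open what actual value any of the four would give, and whether any change to the shared core would bring a reading within the tested range in this assay.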